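Ester side-chain swap from compound 2 to compound 3

The compounds below may be only part of what the source reports. "The series", "measured", "known", "first", "only" and "open" are said of these compounds alone.

Two esters on the shared core have been measured so far. In an ADME assay on HepG2 2.2.15 cells (Homo sapiens) for cytotoxicity (a lower number here means that less compound is tolerated, a higher number that more compound is tolerated), compound 1 (`CCCCC(=O)OCCc1c(-c2ccccc2Cl)c2cc(Cl)ccc2[nH]c1=O`) gives 200000 nM. In this assay, for the measured compounds named here, compound 2 (`O=C(O)CCCC(=O)OCCc1c(-c2ccccc2Cl)c2cc(Cl)ccc2[nH]c1=O`) gives 110000 nM, which lies within the scatter of compound 1, its only neighbour on these numbers.

Compound 3 (`CC(=O)NCC(=O)OCCc1c(-c2ccccc2Cl)c2cc(Cl)ccc2[nH]c1=O`) has acetamido in place of 2-carboxyethyl on a saturated chain carbon bound to a carbonyl carbon. Going by the values given here, no measured compound carries acetamido, so the evidence is indirect. Among the compounds with values here, the one measured step, a 1.8-fold lower number from compound 1 to compound 2 (0.26 log units; within the scatter), placed carboxy in place of methyl on a saturated chain carbon of the same side chain. Within the data shown here, it is the only guide to how far a change in this chain moves the number. Since that step gave a 1.8-fold lower number from compound 1 to compound 2 (0.26 log units; within the scatter) no shift beyond the scatter is expected in this assay, and no direction can be assigned with confidence. The expected step is a 1.2-fold higher number from compound 2 to compound 3 (0.07 log units; within the scatter). For compound 3 the estimated value is 130000 nM, with an expected range of 60000 nM to 260000 nM.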

Compound 3, half-maximal cytotoxic concentration: 110000 nM
For compound 3 the middle estimate is 1.2-fold (0.07 log units) above the measured one, within the range that was stated.
By their numbers in this assay, from the lowest: compounds 2, 3 and 1 (each within the scatter of the next).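

Notes on the side chain: at the saturated chain carbon bound to a carbonyl carbon, this assay gives no change at the digits printed from compound 2 to compound 3 (within the scatter) for acetamido in place of 2-carboxyethyl, and a 1.8-fold lower number from compound 1 to compound 3 (0.26 log units; within the scatter) for acetamido in place of propyl. The earlier pair covered only an alkyl chain and a carboxy-ended chain; with a nitrogen-bearing acetamido group added, all three esters now lie within the scatter of one another, and none of the three groups at this place separates from the others in this assay. No measurement at hand bears on why these side chains read alike.

Still open, from the compounds shown here alone, is whether a free primary amine, a phenyl ring or a much longer alkyl chain at this same place would give a step beyond the scatter, since the three groups compared here are all open-chain. Also open, going by these compounds, is how the free hydroxyethyl compound, without any ester on the shared core, would read in this assay against these three esters.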